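Working notes: from compound 2 to compound 3

The compounds below may be only part of what the source reports. "The series", "measured", "known", "first", "only" and "open" are said of these compounds alone.

Measured so far in a physicochemical assay, with a stated time of 6 min; on this read-out lower numbers stand for stronger inhibition and higher numbers for weaker inhibition:
- compound 1 (`O=C(Nc1nc(-c2cc3ccccc3o2)cs1)Nc1ccccc1F`) gives 2630 nM
- compound 2 (`O=C(Nc1cccc(F)c1)Nc1nc(-c2cc3ccccc3o2)cs1`) gives 4520 nM

Within the data shown here, with only two numbers in hand, compound 2 has a single measured neighbour, and the two values lie within the scatter of each other. The next compound to be read is compound 3 (`Cc1ccc(NC(=O)Nc2nc(-c3cc4ccccc4o3)cs2)cc1`). The structural change is 4-methylphenyl in place of 3-fluorophenyl on an amide-type nitrogen.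

Among the measured compounds shown here, one measured step bears on this: 3-fluorophenyl in place of 2-fluorophenyl at that same kind of nitrogen, which stayed within the scatter (a 1.7-fold higher number from compound 1 to compound 2 (0.24 log units; within the scatter)). For the measured compounds named here, no measured compound carries 4-methylphenyl, so this evidence is thin and covers only a fluorine-bearing pair. On that basis, no step beyond the scatter is expected in this assay, and no direction can be argued with any confidence. The step expected is a 1.3-fold lower number from compound 2 to compound 3 (0.11 log units; within the scatter), a small one. For compound 3 the estimated value is 3500 nM, with an expected range from 1300 nM to 9000 nM.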

Compound 3, half-maximal inhibitory concentration: 500 nM
The estimate for compound 3 lay 7.0-fold (0.85 log units) above the measured number, outside the stated range (below it).
By their numbers in this assay, from the lowest: compound 3; then compounds 1 and 2 (each within the scatter of the next).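

In this assay, the group on the amide-type nitrogen proves able to move the read-out beyond the scatter: 4-methylphenyl in place of 3-fluorophenyl gives a 9.0-fold lower number from compound 2 to compound 3 (0.96 log units; beyond the scatter) and 4-methylphenyl in place of 2-fluorophenyl gives a 5.3-fold lower number from compound 1 to compound 3 (0.72 log units; beyond the scatter) on the same shared core. The two fluorophenyl compounds alone showed no step beyond the scatter, whereas compound 3 now stands apart from both, with the lowest number of the three and therefore the strongest inhibition among them. Nothing measured here accounts for this difference, so the notes record only its size and direction.

The compounds shown leave open whether the step goes with the methyl group itself or with its place on the ring, as compound 3 differs from each fluorophenyl compound in both the group and its name position. Also open, on these data alone, is how 4-fluorophenyl, 3-methylphenyl, unsubstituted phenyl or 4-ethylphenyl would read at this nitrogen, and whether a ring bearing an amine or a carboxylic acid would keep the lower number seen with 4-methylphenyl.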